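A few compounds are considered here, and "the series" means these few. Any claim that something is new, unique, unknown or untested is made for them only; others in the source may bear on it.

The three compounds that have been measured, and the one that has not, were compared in a functional assay on U-87MG ATCC cells for antiproliferative activity against U-87 MG (Homo sapiens), read by MTT assay, with a stated time of 48 h, tested at 100 uM; on this read-out higher numbers stand for a weaker effect at the one concentration tested and lower numbers for a stronger effect. Compound 1 `Cc1nc(-c2ccccc2)sc1C(=O)CSc1nc(N)c(C#N)c(-c2ccc(Cl)cc2)n1` gives 17.1% in this assay. Compound 2 `Cc1nc(-c2ccc(Cl)cc2)sc1C(=O)CSc1nc(N)c(C#N)c(-c2ccc(Cl)cc2)n1` is compound 1 altered in a single place:

chloro in place of hydrogen on an aromatic carbon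

In this assay compound 2 gives 1.65%. That single alteration produced a number 15.5 percentage points lower from compound 1 to compound 2 (beyond the scatter), so the read-out moved clearly in the direction of a stronger effect.

Compound 3 `Cc1nc(-c2ccccc2)sc1C(=O)CSc1nc(-c2ccc(Cl)cc2)c(C#N)c(=O)[nH]1` is built on a different core from compound 1; the difference between the two cores is not broken down here. In this assay compound 3 gives 22.5%, the highest of the three numbers. Compound 1 sits close to it, within the scatter, while compound 2 sits well below it, beyond the scatter.

Compound 4 `Cc1nc(-c2ccc(Cl)cc2)sc1C(=O)CSc1nc(-c2ccc(Cl)cc2)c(C#N)c(=O)[nH]1` has not yet been measured. It differs from compound 3 in one place:

chloro in place of hydrogen on an aromatic carbon

This is the same change that separates compound 1 from compound 2, now made on the core of compound 3 rather than on that of compound 1. Because that change on the other core gave a number 15.5 percentage points lower from compound 1 to compound 2 (beyond the scatter), a step of similar size is expected here, and the estimate means a number 14.5 percentage points lower from compound 3 to compound 4 (beyond the scatter). This expectation rests on a single measured pair, so the range is kept wide. Compound 4 is expected to give 8%, most likely between 1% and 18%.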

Compound 4, a percentage reported as activity, at one concentration (the size of the read-out at that concentration, not a potency): 12.8%
Compound 4: the middle estimate sits 4.8 percentage points below what was measured; the measured number falls inside the stated range.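

In this assay, setting chloro in place of hydrogen on the core of compound 3 gave a number 9.7 percentage points lower from compound 3 to compound 4 (within the scatter), so on this core alone the step cannot be told apart from the ordinary spread of repeated measurements. Set beside the step on the other core, it does not differ by more than such measurements allow: the same change on two cores in this assay, a number 15.5 percentage points lower (beyond the scatter) from compound 1 to compound 2 and a number 9.7 percentage points lower (within the scatter) from compound 3 to compound 4, 5.8 percentage points apart, within the scatter of two such steps. Among the compounds shown here, this fits the idea that the phenyl to 4-chlorophenyl change carries over from one core to the other, with both numbers moving the same way, but it does not prove this, since each core offers only one pair, only one of the two steps lies beyond the scatter, and a single test concentration says nothing about potency.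

The compounds shown carry only hydrogen or chloro at this place, so they leave open how a fluoro, a methyl or a methoxy group on the same aromatic carbon would read on either core. They also leave open whether a larger or differently built substituent there, such as an amine or a carboxylic acid, would follow the same course on both cores.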